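Ethyl for 4-chlorophenyl on the pyrazole-bearing series

The compounds below may be only part of what the source reports. "The series", "measured", "known", "first", "only" and "open" are said of these compounds alone.

Compound 1 `Cc1ccccc1COc1n[nH]c(=S)n1/N=C/c1c[nH]nc1-c1ccc(Cl)cc1`: 44 ug/mL
Compound 2 `Cc1ccc(COc2n[nH]c(=S)n2/N=C/c2c[nH]nc2-c2ccc(Cl)cc2)cc1`: 28 ug/mL

In a functional assay on HepG2 cells (Homo sapiens) for cytotoxicity, read by MTT assay, with a stated time of 24 h (a higher number here means a weaker inhibitor, a lower number a stronger inhibitor), compound 2 gives the lowest of the two numbers; compound 1 sits within the scatter of it, as shown by a 1.6-fold lower number from compound 1 to compound 2 (0.20 log units; within the scatter). Compound 3 `CCc1n[nH]cc1/C=N/n1c(OCc2ccc(C)cc2)n[nH]c1=S` differs from compound 2 by ethyl in place of 4-chlorophenyl on an aromatic carbon. Within the data shown here, the only measured step concerns the benzyl ether and does not touch this position, so no step bears on the change directly. A loss of the aromatic group is expected to weaken cytotoxicity modestly, as a 1.6-fold higher number from compound 2 to compound 3 (0.21 log units; within the scatter). Compound 3 is therefore estimated at 45 ug/mL, with a range from 20 ug/mL to 100 ug/mL.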

Compound 3, half-maximal inhibitory concentration: > 100 ug/mL
Compound 3 was reported as a limit; the forecaster's own chance of this, stated with the estimate: 15%; at least 2.2-fold (0.34 log units) between middle value and limit.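

Where exchanging 2-methylphenyl for 4-methylphenyl stayed within the scatter, the aromatic carbon on the five-membered ring proves sensitive in this assay: ethyl in place of 4-chlorophenyl gives an at least 3.5-fold higher number from compound 2 to compound 3 (0.55 log units; beyond the scatter). Compound 3 is reported only as a limit, so this step has a lower bound but no fixed size: the limit of > 100 ug/mL in this assay, at which 1 of the 3 values shown sits.

The compounds shown leave open whether the chlorine, the aromatic ring or the size of the group accounts for the difference; an unsubstituted phenyl or a butyl chain at this carbon would separate these. Going by these compounds, whether the step holds with 2-methylphenyl on the ether also remains open.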